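A propyl group added to the triazole of compound 3

The compounds below may be only part of what the source reports. "The series", "measured", "known", "first", "only" and "open" are said of these compounds alone.

Among the measured compounds shown here, compound 3 `c1ccc(C(c2ccccc2)n2ccnn2)cc1` gives 4580 nM in an assay on isolated protein for inhibition of Aromatase (Homo sapiens), read by fluorescence and colorimetric assay, with a stated time of 30 min (on this read-out lower numbers stand for stronger inhibition and higher numbers for weaker inhibition), the lowest of the three numbers measured so far. Compound 2 `N#Cc1ccc(C(c2ccc(C#N)cc2)n2cc(COc3ccc(Cl)cc3)nn2)cc1` gives 16100 nM and compound 1 `N#Cc1ccc(C(c2ccc(C#N)cc2)n2cc(C3CCCCC3)nn2)cc1` gives 19300 nM; both carry a nitrile on each aryl ring of the shared core and a large group on the triazole, so neither is a single-point relative of compound 3. Compound 4 `CCCc1cn(C(c2ccccc2)c2ccccc2)nn1` differs from compound 3 by propyl in place of hydrogen on an aromatic carbon, on an aromatic carbon of a five-membered aromatic ring with 3 nitrogen. For the measured compounds named here, the only measured step, a 1.2-fold lower number from compound 1 to compound 2 (0.08 log units; within the scatter), compares two large groups at that ring carbon and says little about adding a short chain to an unsubstituted ring. Compounds 1 and 2 do carry groups there and show higher numbers than compound 3, but their core differs as well, so that comparison is confounded. The expected step is therefore modest, a 1.5-fold higher number from compound 3 to compound 4 (0.18 log units; within the scatter), toward a higher number, with a wide range. Compound 4 is estimated at 7000 nM, between 2500 nM and 20000 nM.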

Compound 4, half-maximal inhibitory concentration: 11000 nM
The estimate for compound 4 lay 1.6-fold (0.20 log units) below the measured number; the measured number falls inside the stated range.
By their numbers in this assay, from the lowest: compound 3; then compounds 4, 2 and 1 (each within the scatter of the next).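

In this assay, among the compounds shown here, propyl in place of hydrogen on the aromatic carbon gives a 2.4-fold higher number from compound 3 to compound 4 (0.38 log units; beyond the scatter), the first reading of a group against hydrogen at this position with nothing else changed; the earlier step compared only two large groups. At this carbon, then, the hydrogen of compound 3 goes with the lower number, and even a chain of 3 carbon carries a cost beyond the scatter. Nothing at hand explains the change.

As far as these compounds go, whether a methyl group, a longer chain or an amine at this carbon would move the number further on the core of compound 3 stays open. Compounds 1 and 2 differ from compound 4 in more than one place, so what the nitrile on each aryl ring contributes cannot be read.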